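Branching the Ester Chain of Compound 3

The compounds below may be only part of what the source reports. "The series", "measured", "known", "first", "only" and "open" are said of these compounds alone.

Of the compounds shown here, three have so far been measured in an assay on membranes from HEK293 cells for displacement of a labelled ligand from adenosine receptor A2b (Homo sapiens), read by scintillation counting, with a stated time of 30 min, tested at 1 uM; a lower number here means less inhibition, a higher number more inhibition at the concentration tested (going by the name of the read-out). Compound 1 `COC(=O)C1=C(C)NC(=O)NC1c1ccoc1` gives 42%. Going by the values given here, compound 2 `COC(=O)C1=C(C)NC(=O)NC1c1cccs1` gives 19%; the only single-point step among the measured compounds, a number 23 percentage points lower from compound 1 to compound 2 (beyond the scatter), comes with thiophen-2-yl in place of furan-3-yl on a saturated ring carbon. Compound 3 `CCCOC(=O)C1=C(C)NC(=S)NC1c1ccco1` gives 46%, the highest of the three numbers; its gap to compound 1 lies within the scatter, while its gap to compound 2 lies beyond it, so the number of compound 3 cannot be called higher than that of every other compound in the set.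

Compound 4 `CC1=C(C(=O)OCC(C)C)C(c2ccco2)NC(=S)N1` has not yet been measured. It differs from compound 3 in one place: methyl in place of hydrogen on a saturated chain carbon bound to two saturated chain carbons. Among the compounds with values here, the one measured step concerns the aryl group on a saturated ring carbon and says nothing about the ester chain, and no pair of measured compounds differs only in that chain, so no step in the data bears directly on this change. With nothing to lean on, a step of a number 1 percentage points lower from compound 3 to compound 4 (within the scatter) is expected, that is, none beyond the scatter. Compound 4 is therefore estimated to give 45% in this assay, with a range from 25% to 65%.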

Compound 4, a percentage reported as inhibition, at one concentration (the size of the read-out at that concentration, not a potency): 18%
Compound 4: middle estimate off by 27 percentage points, on the high side; measured number outside the range, below it.
By their numbers in this assay, from the lowest: compounds 4 and 2 (each within the scatter of the next); then compounds 1 and 3 (each within the scatter of the next).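

In this assay, the ester chain proves to be a position that responds to a very small change: a number 28 percentage points lower from compound 3 to compound 4 (beyond the scatter), and the only alteration is methyl in place of hydrogen on a saturated chain carbon bound to two saturated chain carbons. The earlier compounds had shown a step beyond the scatter only for the aryl group, in a number 23 percentage points lower from compound 1 to compound 2 (beyond the scatter), whereas this pair shows that propoxy to isobutoxy alone, with the rest of compound 3 kept, is also enough to produce one. No measurement available here explains why this single methyl lowers the number.

The compounds shown leave open whether the branch itself matters or whether any further carbon on the chain would do the same, a question that a straight butyl ester, set against both compound 3 and compound 4, could separate. They also leave open whether the same change acts alike with the other aryl groups or with the carbonyl in place of the thiocarbonyl, and whether a more heavily branched tert-butyl ester or a cyclopropylmethyl ester would follow compound 4.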